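Bromophenoxy to methylphenylamino on the aryl ether series

This account rests on a few compounds, and the source may have more. Where it says the series, first, only, none or still open, it means among the compounds named here.

Measured compounds in a functional assay on HEK293 cells for antagonist activity at thromboxane A2 receptor (Homo sapiens), read by fluorescence and calcium flux; on this read-out lower numbers stand for stronger inhibition and higher numbers for weaker inhibition:
compound 1, `Cc1ccc(Oc2ccc(C#N)cc2S(=O)(=O)NC(=O)NC(C)(C)C)cc1`: 750 nM
compound 2, `CC(C)(C)NC(=O)NS(=O)(=O)c1cc(C#N)ccc1Oc1ccc(F)cc1`: 4350 nM
compound 3, `CC(C)(C)NC(=O)NS(=O)(=O)c1cc(C#N)ccc1Oc1ccc(Br)cc1`: 5880 nM

Compound 3 gives the highest of the three numbers; compound 2 sits within the scatter of it, while compound 1 lies well apart, as a 7.8-fold higher number from compound 1 to compound 3 (0.89 log units; beyond the scatter) and a 1.4-fold higher number from compound 2 to compound 3 (0.13 log units; within the scatter) show.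

Compound 4, `Cc1ccc(Nc2ccc(C#N)cc2S(=O)(=O)NC(=O)NC(C)(C)C)cc1`, is not yet measured. The change is (4-methylphenyl)amino in place of 4-bromophenoxy on an aromatic carbon. Among the compounds with values here, two parts are bundled: the bromo reverts to methyl, for which a 7.8-fold higher number from compound 1 to compound 3 (0.89 log units; beyond the scatter) is the direct precedent, and the oxygen link becomes an amino link, which no measured pair covers. If the first part dominates, a return toward compound 1 is expected, and the uncovered linker change widens the range. Compound 4 is thus expected at 900 nM, with a range of 250 nM to 3500 nM, meaning an estimated step of a 6.5-fold lower number from compound 3 to compound 4 (0.82 log units; beyond the scatter).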

Compound 4, half-maximal inhibitory concentration: 850 nM
Compound 4: middle estimate off by 1.1-fold (0.02 log units), on the high side, within the range that was stated.
By their numbers in this assay, from the lowest: compounds 1 and 4 (each within the scatter of the next); then compounds 2 and 3 (each within the scatter of the next).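

In this assay the link now has a direct pair: with the 4-methylphenyl ring kept, amino in place of oxygen gives a 1.1-fold higher number from compound 1 to compound 4 (0.05 log units; within the scatter), so the two links cannot be told apart at this position. The (4-methylphenyl)amino compound also stands clear of both halogenated ethers, with a 6.9-fold lower number from compound 3 to compound 4 (0.84 log units; beyond the scatter) and a 5.1-fold lower number from compound 2 to compound 4 (0.71 log units; beyond the scatter), so the gap tracks the ring substituent across these compounds. Nothing available explains this gap.

Still open, going by these compounds, is whether the amino link matches the oxygen link on 4-fluorophenyl and 4-bromophenyl rings. Also open, on these data alone, is how an ethyl or methoxy group in place of the ring methyl would read.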